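Notes on compounds 1, 2 and 3 in one cell assay

The compounds below may be only part of what the source reports. "The series", "measured", "known", "first", "only" and "open" are said of these compounds alone.

Compound 1 `CCOC(=O)C1=Cc2ccccc2OC1(OCc1cn(CC(=O)Nc2ccc(C)cc2)nn1)C(F)(F)F`: 54300 nM
Compound 2 `CCOC(=O)C1=Cc2ccccc2OC1(OCc1cc(-c2ccc(Br)cc2)no1)C(F)(F)F`: > 150000 nM

In a functional assay on A549 cells (Homo sapiens) for inhibition, read by MTT assay, with a stated time of 24 h (on this read-out lower numbers stand for stronger inhibition and higher numbers for weaker inhibition), compound 1 gives 54300 nM, the only full number shown for the series. Compound 2 is reported only as a limit of the assay, (the limit of > 150000 nM in this assay, at which 1 of the 2 values shown sits). Compound 3 `CCOC(=O)C1=Cc2ccccc2OC1(OCc1cn(-c2cccc(C(F)(F)F)c2)nn1)C(F)(F)F` is not yet measured. It differs from compound 1 by 3-(trifluoromethyl)phenyl in place of ((4-methylphenyl)carbamoyl)methyl on an aromatic nitrogen. Within the data shown here, no measured step between compounds differing in one place exists here, so the change has no precedent in this assay. Compound 3 is expected to sit near compound 1, with the step from compound 1 to compound 3 estimated at a 1.2-fold higher number from compound 1 to compound 3 (0.08 log units; within the scatter), hardly beyond the scatter. The estimate for compound 3 is 65000 nM, range 20000 nM to 150000 nM.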

Compound 3, half-maximal inhibitory concentration: > 150000 nM
Compound 3: only a limit was reported; the forecaster's own chance of this, stated with the estimate: 35%; middle value at least 2.3-fold (0.36 log units) away from the limit.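

Among these compounds, on an aromatic nitrogen of a five-membered aromatic ring with 3 nitrogen, 3-(trifluoromethyl)phenyl in place of ((4-methylphenyl)carbamoyl)methyl gives the first one-place comparison in this assay: an at least 2.7-fold higher number from compound 1 to compound 3 (0.44 log units; beyond the scatter). Going by these compounds, the value for compound 3 is a limit of the assay, so the true size of this step stays unknown. The series now gathers at that limit: the limit of > 150000 nM in this assay, at which 2 of the 3 values shown sit.

On these data alone, it remains open which part of the ((4-methylphenyl)carbamoyl)methyl group, the amide hydrogen, the carbonyl or the 4-methylphenyl ring, matters for the number seen with compound 1. Also open, as far as these compounds go, is how an amine or a carboxylic acid on the same nitrogen would read.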